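Halogen exchange on the fused core of compound 1

The source may hold more compounds than are shown below. What is called first, only, known or untested is meant among the compounds shown, and "the series" means these compounds.

Compound 1 `C[C@H]1O[C@@H](n2c(Br)nc3cc(Cl)c(Cl)cc32)[C@H](O)[C@@H]1O` stands at the edge of a functional assay on KB cells (Homo sapiens) for inhibition (a higher number here means a weaker inhibitor, a lower number a stronger inhibitor), where it gives > 100000 nM, which is a limit of the assay and not a number. Compound 2 `C[C@@H]1O[C@@H](n2c(Br)nc3cc(Cl)c(Cl)cc32)[C@H](O)[C@@H]1O` gives 60000 nM. Compound 3 `CSc1nc2cc(Cl)c(Cl)cc2n1[C@@H]1O[C@@H](CO)[C@@H](O)[C@H]1O` gives > 100000 nM, again a limit of the assay. Among the compounds with values here, the only measured step, an at least 1.6-fold lower number from compound 1 to compound 2 (0.22 log units; that floor lies within the scatter), rests on the fact that compounds 1 and 2 differ only in the configuration as drawn and reaches no more than a floor set by the limit of > 100000 nM in this assay, at which 2 of the 3 values shown sit. Compound 4 `C[C@H]1O[C@@H](n2c(Cl)nc3cc(Cl)c(Cl)cc32)[C@H](O)[C@@H]1O` differs from compound 1 by chloro in place of bromo on an aromatic carbon. Within the data shown here, no measured step involves such an exchange, so no direction can be drawn from the measured compounds; the expectation is no step beyond the scatter, with compound 4 likely also reported as a limit. The step that the limit leaves unreadable from compound 1 to compound 4 is therefore expected to be small. The estimate for compound 4 in this assay is 150000 nM, within 50000 nM to 400000 nM.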

Compound 4, half-maximal inhibitory concentration: 75000 nM
Compound 4: the middle estimate sits 2.0-fold (0.30 log units) above what was measured; the measured number falls inside the stated range.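

In this assay, chloro in place of bromo, on an aromatic carbon between two ring nitrogen atoms, gives an at least 1.3-fold lower number from compound 1 to compound 4 (0.12 log units; that floor lies within the scatter). Within the data shown here, compound 4 gives 75000 nM, a number and not a limit, so this exchange gives the first reading at this position, though no direction beyond the scatter. The full size of the step stays unreadable, and only a floor can be given: the limit of > 100000 nM in this assay, at which 2 of the 4 values shown sit.

Open, on these data alone, is whether an amine or a carboxylic acid at this position would move the number beyond the scatter. Also open, as far as these compounds go, is whether a longer chain there would do so.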